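A Methyl-to-Hydrogen Change and Its Expected Effect

The source may report more compounds than this note shows. Statements on the series, on what has been measured and on what is new or still open speak of the compounds shown alone.

Measured compounds:
- compound 1, `COc1cc(-c2nn(-c3cccc(NC(=O)Nc4cc(C(F)(F)F)cc(C(F)(F)F)c4)c3)cc2-c2ccncc2)ccc1Cl`: 711 nM
- compound 2, `O=C(Nc1cccc(-n2cc(-c3ccncc3)c(-c3ccc(Cl)c(O)c3)n2)c1)Nc1cc(C(F)(F)F)cc(C(F)(F)F)c1`: 983 nM
- compound 3, `COc1cc(-c2nn(-c3cccc(NC(=O)Nc4ccc(Cl)c(C(F)(F)F)c4)c3)cc2-c2ccncc2)ccc1Cl`: 1240 nM

Of the compounds shown here, three have so far been tested in a functional assay on SNB-19 cells (Homo sapiens) for inhibition, read by sulforhodamine B assay, with a stated time of 48 h; a lower number here means a stronger inhibitor of growth, a higher number a weaker inhibitor of growth. Compound 1, with the structure `COc1cc(-c2nn(-c3cccc(NC(=O)Nc4cc(C(F)(F)F)cc(C(F)(F)F)c4)c3)cc2-c2ccncc2)ccc1Cl`, gives 711 nM in this assay. Compound 2, `O=C(Nc1cccc(-n2cc(-c3ccncc3)c(-c3ccc(Cl)c(O)c3)n2)c1)Nc1cc(C(F)(F)F)cc(C(F)(F)F)c1`, gives 983 nM, and compound 3, `COc1cc(-c2nn(-c3cccc(NC(=O)Nc4ccc(Cl)c(C(F)(F)F)c4)c3)cc2-c2ccncc2)ccc1Cl`, gives 1240 nM. All three numbers lie close together, and none of the gaps between them is large enough to call one compound a stronger growth inhibitor than another.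

Compound 2 is made from compound 1 by a single change: hydrogen in place of methyl on an oxygen on an aromatic ring. That change gave a 1.4-fold higher number from compound 1 to compound 2 (0.14 log units; within the scatter). Compound 3 carries a different substituent on the other end of the molecule than compound 1; the difference between the two cores is not broken down here, and the two values simply sit close to each other.

Compound 4, `O=C(Nc1cccc(-n2cc(-c3ccncc3)c(-c3ccc(Cl)c(O)c3)n2)c1)Nc1ccc(Cl)c(C(F)(F)F)c1`, has not yet been measured. It stands to compound 3 exactly as compound 2 stands to compound 1, the change being (hydrogen in place of methyl on an oxygen on an aromatic ring), at the same place. Compound 4 is therefore expected to show a 1.4-fold higher number from compound 3 to compound 4 (0.14 log units; within the scatter) because the same change once gave a 1.4-fold higher number from compound 1 to compound 2 (0.14 log units; within the scatter). On that basis compound 4 is estimated at 1700 nM in this assay, with a likely range from 850 nM to 3500 nM.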

Compound 4, concentration for 50% growth inhibition: 1120 nM
For compound 4 the middle estimate is 1.5-fold (0.18 log units) above the measured one, and the stated range covers the measured number.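

Replacing methoxy with hydroxy on the core of compound 3 gives, in this assay, a step that stays within the usual scatter (a 1.1-fold lower number from compound 3 to compound 4 (0.04 log units; within the scatter)), so the two compounds cannot be told apart as growth inhibitors. Set beside the earlier step, the same swap reads alike on both cores: the same change on two cores in this assay, a 1.4-fold higher number (0.14 log units; within the scatter) from compound 1 to compound 2 and a 1.1-fold lower number (0.04 log units; within the scatter) from compound 3 to compound 4, 1.5-fold (0.18 log units) apart, within the scatter of two such steps. This shows that, on these two cores, the swap from 4-chloro-3-methoxyphenyl to 4-chloro-3-hydroxyphenyl has no effect that this read-out can resolve, and that this lack of a clear effect carries from one core to the other; it does not show that a large effect would carry over in the same way, that the two groups would stay interchangeable on other cores, or why the numbers stay so close.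

The compounds shown leave open what happens when the oxygen on the aromatic ring carries something other than hydrogen or methyl, such as an ethyl group or a longer chain, or when an amine or a carboxylic acid takes the place of the methoxy group. They also leave open whether the same picture would hold in cell lines other than this one.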